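The source may hold more compounds than are shown below. What is called first, only, known or untested is meant among the compounds shown, and "the series" means these compounds.

In a functional assay on OVCAR-8 cells (Homo sapiens) for inhibition (a lower number here means a stronger inhibitor of growth, a higher number a weaker inhibitor of growth), compound 2, `COc1ccc(-c2cn(-c3cccc(C(=O)/C=C/c4ccc(O)c(OC)c4)c3)c(=O)[nH]2)cc1`, gives 4970 nM, the higher of the two numbers recorded so far. Compound 1, `O=C(/C=C/c1cccc(O)c1)c1cccc(-n2cc(-c3ccc(Cl)cc3)[nH]c2=O)c1`, gives 990 nM in this assay, a difference between the two that lies beyond the usual scatter. Compound 3, `COc1cc(/C=C/C(=O)c2cccc(-n3cc(-c4ccc(Cl)cc4)[nH]c3=O)c2)ccc1O`, differs from compound 2 by chloro in place of methoxy on an aromatic carbon. Among the measured compounds shown here, since no measured pair isolates this single change, only a cautious expectation is possible: a modest move toward a lower number, about a 2.3-fold lower number from compound 2 to compound 3 (0.35 log units; beyond the scatter). Compound 3 is therefore expected to give roughly 2200 nM in this assay, within a range from 800 nM to 5500 nM.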

Compound 3, concentration for 50% growth inhibition: 4180 nM
Beside the measured number, compound 3's estimate is 1.9-fold (0.28 log units) below it; the range from low to high includes it.
By their numbers in this assay, from the lowest: compound 1; then compounds 3 and 2 (each within the scatter of the next).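

In this assay, chloro in place of methoxy on the aromatic carbon para to a large group gives a 1.2-fold lower number from compound 2 to compound 3 (0.08 log units; within the scatter), so this change does not separate the two compounds. The other end of the molecule does show an effect: 4-hydroxy-3-methoxyphenyl in place of 3-hydroxyphenyl gives a 4.2-fold higher number from compound 1 to compound 3 (0.63 log units; beyond the scatter). Nothing available explains either result. Still open, on these data alone, is how an amine or a carboxylic acid at the para place would compare, and whether methoxy in place of chloro would also matter little alongside the 3-hydroxyphenyl of compound 1.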